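A few compounds are considered here, and "the series" means these few. Any claim that something is new, unique, unknown or untested is made for them only; others in the source may bear on it.

Measured so far in a functional assay on MCF7 cells (Homo sapiens) for antiproliferative activity, with a stated time of 48 h; a higher number here means a weaker inhibitor, a lower number a stronger inhibitor:
compound 1 `CC(C)(C)c1ccc(CNC(=O)NC(=O)CCl)cc1` gives 2800 nM.
compound 3 `CCCCC(OC)c1cccc(NC(=O)CCl)c1` gives 12000 nM.
compound 2 `CCCCC(O)c1cccc(NC(=O)NC(=O)CC)c1` gives > 100000 nM, which is a limit of the assay and not a number (the limit of > 100000 nM in this assay, at which 1 of the 3 values shown sits).

Of the two numbers, compound 3 gives the higher one; compound 1 gives the lower, and the gap between them lies beyond the scatter. Compound 4 `C=CC(=O)Nc1cccc(C(CCCC)OC)c1` differs from compound 3 by vinyl in place of chloromethyl on a carbonyl carbon, so the ((chloromethyl)carbonyl)amino group becomes a (vinylcarbonyl)amino group. Going by the values given here, no measured pair shows this exchange, so its direction is open; in this assay a step of about the scatter, or a modest weakening, is expected, a 1.5-fold higher number from compound 3 to compound 4 (0.18 log units; within the scatter). Compound 4 is accordingly estimated at 18000 nM, with a range from 4000 nM to 80000 nM.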

Compound 4, half-maximal inhibitory concentration: > 100000 nM
Compound 4 ended at the assay's limit; the forecaster's own chance of this, stated with the estimate: 15%; at least 5.5-fold (0.74 log units) between middle value and limit.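

Going by these compounds alone, with the rest of compound 3 unchanged, vinyl in place of chloromethyl on a carbonyl carbon gives an at least 8.3-fold higher number from compound 3 to compound 4 (0.92 log units; beyond the scatter) in this assay, the first one-place comparison. From the compounds shown here alone, its true size remains unknown, as compound 4 gives a limit and not a number: the limit of > 100000 nM in this assay, at which 2 of the 4 values shown sit. Of the two groups, only chloromethyl leaves a measurable value at this position.

Going by these compounds, whether bromomethyl or a plain methyl on the same carbonyl carbon would keep a measurable value stays open. On these data alone, whether the same exchange on the core of compound 1 would cost as much also stays open.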